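This account rests on a few compounds, and the source may have more. Where it says the series, first, only, none or still open, it means among the compounds named here.

Compound 1 `OC[C@H]1O[C@@H](n2cnc3c(NCc4ccccc4F)ncnc32)[C@H](O)[C@@H]1O` gives in a functional assay on MCF cells (Homo sapiens) for antiproliferative activity, with a stated time of 72 h (a lower number here means a stronger inhibitor, a higher number a weaker inhibitor), a value of > 166000 nM, which is a limit of the assay and not a number.
Compound 2 `OC[C@H]1O[C@@H](n2cnc3c(NCc4ccc(Cl)c(Cl)c4)ncnc32)[C@H](O)[C@@H]1O` gives 88800 nM in this assay.
Compound 3 `COc1cccc(CNc2ncnc3c2ncn3[C@@H]2O[C@H](CO)[C@@H](O)[C@H]2O)c1OC` gives > 166000 nM in this assay, again a limit of the assay.

Compound 3 thus stands at the limit of this assay, the same limit at which most of the values sit (the limit of > 166000 nM in this assay, at which 2 of the 3 values shown sit). Compound 4 `OC[C@H]1O[C@@H](n2cnc3c(NCc4cc(O)cc(O)c4)ncnc32)[C@H](O)[C@@H]1O` differs from it in one place: 3,5-dihydroxyphenyl in place of 2,3-dimethoxyphenyl on a saturated chain carbon bound to a nitrogen on an aromatic ring. The measured steps that bear on this change are an at least 1.8-fold higher number from compound 2 to compound 3 (0.27 log units; that floor lies within the scatter), which runs into the limit, and a step that the two limits leave unreadable from compound 1 to compound 3, which joins two limits. For the measured compounds named here, neither step involves a 3,5-dihydroxyphenyl, and the only full number among the measured compounds is that of compound 2, so the change gives no read on direction. Compound 4 is therefore expected to stay near the limit, the step of an at least 1.1-fold lower number from compound 3 to compound 4 (0.04 log units; that floor lies within the scatter) being an expected change of no size beyond the scatter. The estimate for compound 4 in this assay is 150000 nM, with a range from 60000 nM to 400000 nM, and a fair chance that only a limit is reported.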

Compound 4, half-maximal inhibitory concentration: > 166000 nM
Compound 4: only a limit was reported; the forecaster's own chance of this, stated with the estimate: 60%; middle value at least 1.1-fold (0.04 log units) away from the limit.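

Compound 4 adds a third compound at the limit in this assay, this time one whose 3,5-dihydroxyphenyl carries hydrogen-bond donors that the 2,3-dimethoxyphenyl lacks: the limit of > 166000 nM in this assay, at which 3 of the 4 values shown sit. The steps joining compound 4 to compound 1 and to compound 3 link limits and cannot be read, so this change shows neither a size nor a direction. For the compounds shown here, the one readable step is an at least 1.8-fold higher number from compound 2 to compound 4 (0.27 log units; that floor lies within the scatter), and compound 2 remains the only compound with a full number, 88800 nM.

The compounds shown leave open whether that full number goes with the two chlorines of the 3,4-dichlorophenyl or with some other feature of that group. They also leave open how a trifluoromethyl group or an amine on the phenyl ring, or a longer chain in place of the saturated chain carbon, would read here.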